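Aryl group change from compound 2 to compound 3

A few compounds are considered here, and "the series" means these few. Any claim that something is new, unique, unknown or untested is made for them only; others in the source may bear on it.

In a functional assay on HT-29 cells (Homo sapiens) for antiproliferative activity, read by MTT assay, with a stated time of 72 h (on this read-out higher numbers stand for weaker inhibition and lower numbers for stronger inhibition), compound 1 `COc1ccc(N2CCN(C(=S)SCc3ccc4nc(N)nc(N)c4c3)CC2)cc1` gives 1770 nM and compound 2 `CC(=O)c1ccc(N2CCN(C(=S)SCc3ccc4nc(N)nc(N)c4c3)CC2)cc1` gives 2280 nM. These two values cannot be separated, so compound 2 stands level with compound 1 on the numbers available.

The next compound is compound 3 `Nc1nc(N)c2cc(CSC(=S)N3CCN(c4ccccc4[N+](=O)[O-])CC3)ccc2n1`, which has 2-nitrophenyl in place of 4-acetylphenyl on an amine nitrogen in a ring.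

For the measured compounds named here, one measured step bears on this change, and only indirectly. With acetyl in place of methoxy on an aromatic carbon, the series moved a 1.3-fold higher number from compound 1 to compound 2 (0.11 log units; within the scatter). That step shows one exchange on the aryl group that left the number within the scatter. Going by the values given here, no measured compound carries 2-nitrophenyl, so the data do not test this group directly, and the range has to stay wider than that single step. On the evidence of that step, no change beyond the scatter is expected in this assay, and neither direction is favoured. The expected change is a 1.1-fold lower number from compound 2 to compound 3 (0.06 log units; within the scatter). Compound 3 is estimated at 2000 nM, with an expected range of 700 nM to 5500 nM.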

Compound 3, half-maximal inhibitory concentration: 4310 nM
Compound 3: the middle estimate sits 2.2-fold (0.33 log units) below what was measured; the range from low to high includes it.
By their numbers in this assay, from the lowest: compounds 1, 2 and 3 (each within the scatter of the next, the first and the last beyond it).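

In this assay, the aryl group on the amine nitrogen of the six-membered ring now has its first exchange beyond the scatter: 2-nitrophenyl in place of 4-methoxyphenyl gives a 2.4-fold higher number from compound 1 to compound 3 (0.39 log units; beyond the scatter). Against 4-acetylphenyl, the same group cannot be separated, with a 1.9-fold higher number from compound 2 to compound 3 (0.28 log units; within the scatter), so compound 2 is not distinguished from either compound 1 or compound 3, and only the comparison of compound 1 with compound 3 carries a modest difference at this position. Nothing available here accounts for that difference.

As far as these compounds go, it remains open whether the step to compound 3 belongs to the nitro group itself or to its place on the phenyl ring, a question on which 4-nitrophenyl would bear directly. Also open, from the compounds shown here alone, is how the series responds to aryl groups further from these three, such as unsubstituted phenyl or 4-aminophenyl, or to a benzyl group on the same nitrogen, since all three compounds here carry a substituted phenyl ring joined directly to it.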